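The source may report more compounds than this note shows. Statements on the series, on what has been measured and on what is new or still open speak of the compounds shown alone.

Compound 1 `O=C(CSc1nnc(-c2ccncc2)o1)N/N=C/c1ccc([N+](=O)[O-])cc1`: 195000 nM
Compound 2 `O=C(CSc1nnc(-c2ccncc2)o1)N/N=C/c1cc(Br)cc(Br)c1O`: 190000 nM

Both values come from an ADME assay on NIH3T3 cells (Mus musculus) for cytotoxicity, read by MTT assay, with a stated time of 24 h; a lower number here means a stronger inhibitor, a higher number a weaker inhibitor. Only these two numbers are available so far, and they lie within the scatter of each other, so compound 2 stands level with compound 1 and neither can be ranked above the other.

Compound 3 `O=C(CSc1nnc(-c2ccncc2)o1)N/N=C/c1ccc(Cl)cc1Cl` has not yet been measured. It keeps the shared core but carries 2,4-dichlorophenyl in place of 3,5-dibromo-2-hydroxyphenyl on a carbon with a double bond to nitrogen.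

Within the data shown here, one measured step bears on this change, since it exchanges the group at that same place: a 1.0-fold lower number from compound 1 to compound 2 (0.01 log units; within the scatter), which is within the scatter. Compound 1 gives 195000 nM and compound 2 gives 190000 nM, so two different groups at this place have left the number unmoved. No step beyond the scatter is therefore expected, although a single step is thin evidence and the range has to stay wide. The expected change is a 1.1-fold lower number from compound 2 to compound 3 (0.02 log units; within the scatter). For compound 3 the estimated value is 180000 nM, with an expected range from 70000 nM to 350000 nM.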

Compound 3, half-maximal inhibitory concentration: 221000 nM
The estimate for compound 3 lay 1.2-fold (0.09 log units) below the measured number; low and high end bracket the measured number.
By their numbers in this assay, from the lowest: compounds 2, 1 and 3 (each within the scatter of the next).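

In this assay the exchange at this place gives a 1.2-fold higher number from compound 2 to compound 3 (0.07 log units; within the scatter) and, measured against the nitro compound, a 1.1-fold higher number from compound 1 to compound 3 (0.05 log units; within the scatter); three different groups on the carbon with a double bond to nitrogen now stand level, where earlier there were only two. The change also goes further than the earlier step in what it removes: 3,5-dibromo-2-hydroxyphenyl has 1 hydrogen-bond donor and 1 hydrogen-bond acceptor, 2,4-dichlorophenyl has 0 of each, and chlorine replaces bromine, yet no step beyond the scatter appears among these three compounds. No supporting measurement bears on this result, so nothing can be said about a cause.

As far as these compounds go, all three groups at this place are substituted phenyl rings, so it remains open whether an amine, a carboxylic acid or a longer chain of carbon atoms there would move the number at all. The shared core is the same in all three compounds, which leaves open what a change elsewhere in it would do in this assay.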